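The source may report more compounds than this note shows. Statements on the series, on what has been measured and on what is new or still open speak of the compounds shown alone.

Compound 1 `O=C(c1ccc(F)cc1)c1ccn(-c2ccc3c(c2)B(O)OC3)c1` in an ADME assay on L929 cells (Mus musculus) for cytotoxicity, read by resazurin assay, with a stated time of 72 h (on this read-out lower numbers stand for stronger inhibition and higher numbers for weaker inhibition), gives > 10 ug/mL, which is a limit of the assay and not a number. Compound 2 `CCCC(=O)c1ccn(-c2ccc3c(c2)B(O)OC3)c1` in this assay gives > 10 ug/mL, again a limit rather than a number.

Among the compounds with values here, compound 2 therefore stands at the limit in this assay, and the one further value shown is a limit too; both values sit at the limit of > 10 ug/mL in this assay, at which 2 of the 2 values shown sit, so no ordering between them can be read. The step to compound 3 `CCCCCC(=O)c1ccn(-c2ccc3c(c2)B(O)OC3)c1` is ethyl in place of hydrogen on a saturated chain carbon, three bonds along the chain from a carbonyl carbon. Within the data shown here, the only measured step, a step that the two limits leave unreadable from compound 1 to compound 2, bears on the carbonyl substituent as well, but its two limits leave its size unreadable, so nothing here shows how much change in this assay a longer chain might bring. Compound 3 is accordingly expected to stay near the limit, with a step that the limit leaves unreadable from compound 2 to compound 3, and its estimated value is 12 ug/mL, in the range 4 ug/mL to 40 ug/mL.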

Compound 3, half-maximal inhibitory concentration: > 10 ug/mL
Compound 3 ended at the assay's limit; the forecaster's own chance of this, stated with the estimate: 65%; the middle value is on the limit's open side.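

Compound 1, compound 2 and compound 3 all end at a limit rather than a number in this assay, so no step among them can be read: the limit of > 10 ug/mL in this assay, at which 3 of the 3 values shown sit.

The compounds shown leave open whether changing the group on the carbonyl carbon shifts the value in this assay at all.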